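Chloro added to a pair of non-toxic oxalamides

This account rests on a few compounds, and the source may have more. Where it says the series, first, only, none or still open, it means among the compounds named here.

Compound 2 `Cc1nc(C(NC(=O)C(=O)Nc2ccc(F)cc2)C2CCCCN2)sc1CCO` is tested in an ADME assay on TZM-b1 cells (Homo sapiens) for cytotoxicity, read by XTT assay, with a stated time of 3 days (a lower number here means that less compound is tolerated, a higher number that more compound is tolerated), and its reading there is a limit of > 88000 nM rather than a number. Compound 1 `Cc1nc(C(NC(=O)C(=O)Nc2ccc(F)c(Cl)c2)C2CCCCN2)sc1CO` likewise gives only a limit, > 77800 nM, in this assay. Compound 3 `Cc1nc(C(NC(=O)C(=O)Nc2ccc(F)c(Cl)c2)C2CCCCN2)sc1CCO` differs from compound 2 by chloro in place of hydrogen on an aromatic carbon. Compound 1 already carries this chloro and sits at the limit of > 77800 nM in this assay, at which 1 of the 2 values shown sits, so no movement beyond the scatter is anticipated. The expected step is a number no higher from compound 2 to compound 3 (the limit leaves the size open), none beyond the scatter. Compound 3 is estimated at 88000 nM, within 40000 nM to 200000 nM, most likely reported again only as a limit.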

Compound 3, half-maximal cytotoxic concentration: > 75800 nM
Compound 3 gave a limit, no number; the forecaster's own chance of this, stated with the estimate: 85%; the middle value lies beyond the limit too.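

In this assay compound 3 gives only a limit, > 75800 nM. Among these compounds, compound 1 and compound 2 also stand as limits, so no step from either to compound 3 can be read. The compounds shown leave open whether either change shifts the half-maximal cytotoxic concentration at all.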